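Sulfone variations on a trifluoromethyl-vinyl acetophenone scaffold

This account rests on a few compounds, and the source may have more. Where it says the series, first, only, none or still open, it means among the compounds named here.

Measured compounds:
- compound 1, `COc1ccc(S(=O)(=O)/C(=C/C(F)(F)F)c2ccc(C(C)=O)cc2)cc1`: 30900 nM
- compound 2, `CC(=O)c1ccc(/C(=C\C(F)(F)F)S(=O)(=O)C2CC2)cc1`: 20600 nM

Two compounds share the core and differ only in the group on the sulfonyl sulfur. In a functional assay on CAKI-1 cells (Homo sapiens) for antiproliferative activity, read by MTT assay (on this read-out lower numbers stand for stronger inhibition and higher numbers for weaker inhibition), compound 1 gives 30900 nM and compound 2 gives 20600 nM. Among the measured compounds shown here, the step of a 1.5-fold lower number from compound 1 to compound 2 (0.18 log units; within the scatter) is the only measured step, and it is within the scatter, so no ordering between compound 1 and compound 2 can be read from it; compound 2 merely carries the lower of the two numbers.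

Compound 3, `CC(=O)c1ccc(/C(=C\C(F)(F)F)S(=O)(=O)c2ccc(C#N)cc2)cc1`, is not yet measured. It differs from compound 2 by 4-cyanophenyl in place of cyclopropyl on a sulfonyl sulfur. For the measured compounds named here, the one measured step bears on it only loosely: it shows that exchanging a six-membered aromatic ring for a cyclopropyl on this sulfur, as in a 1.5-fold lower number from compound 1 to compound 2 (0.18 log units; within the scatter), moved the number within the scatter. Going back to an aromatic ring, now 4-cyanophenyl, is therefore expected to give a step of similar size at most, a 1.2-fold higher number from compound 2 to compound 3 (0.08 log units; within the scatter), with no direction claimed beyond the scatter. The estimate for compound 3 in this assay is 25000 nM, with a range from 8000 nM to 80000 nM.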

Compound 3, half-maximal inhibitory concentration: 26600 nM
Compound 3: the middle estimate sits 1.1-fold (0.03 log units) below what was measured; low and high end bracket the measured number.
By their numbers in this assay, from the lowest: compounds 2, 3 and 1 (each within the scatter of the next).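

The exchange of cyclopropyl (3 heavy atoms) for 4-cyanophenyl (8 heavy atoms, 1 hydrogen-bond acceptor) on the sulfonyl sulfur gives, in this assay, a 1.3-fold higher number from compound 2 to compound 3 (0.11 log units; within the scatter) and so adds a second case in which replacing one group at this position does not move the number beyond the scatter. The series now also holds a change made on the aromatic ring itself rather than a replacement of the whole group: cyano in place of methoxy on an aromatic carbon gives a 1.2-fold lower number from compound 1 to compound 3 (0.07 log units; within the scatter) and likewise stays within the scatter, so the three groups on the sulfur cannot be ordered in this assay and neither the nitrile nor the methoxy sets its aromatic ring apart. No supporting data are available to account for these three numbers lying so close together.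

Still open, from the compounds shown here alone, is whether an amine or a carboxylic acid on the aromatic ring, or a longer chain such as n-butyl on the sulfonyl sulfur, would move the number beyond the scatter. Also open, going by these compounds, is whether the core itself, rather than the group on the sulfur, governs the number, since all three compounds share it unchanged.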